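A few compounds are considered here, and "the series" means these few. Any claim that something is new, unique, unknown or untested is made for them only; others in the source may bear on it.

Working notes on the series. Compound 1 `CC(=O)OCCOn1cnc2c(Cl)nc(N)nc21` has been run in a functional assay on WI-38 cells (Homo sapiens) for inhibition; a higher number here means a weaker inhibitor, a lower number a stronger inhibitor. In this assay compound 1 returns only the limit of > 500000 nM. Compound 2 `CC(O)n1cnc2c(N)nc(I)nc21` in this assay likewise returns only the limit of > 500000 nM. Compound 3 `CC(=O)OCCOn1cnc2c(S)nc(N)nc21` in this assay also sits at the limit of > 500000 nM. Compound 3 thus stands at the same limit as the other two, and no order among the three can be read. The step from compound 1 to compound 3, a step that the two limits leave unreadable from compound 1 to compound 3, is left unreadable by the two limits. The whole set rests on (the limit of > 500000 nM in this assay, at which 3 of the 3 values shown sit).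

Compound 4 `CC(=O)OCCOn1cnc2c(S)nc(F)nc21` is not yet measured. It differs from compound 3 by fluoro in place of amino on an aromatic carbon. Among the compounds with values here, no measured step touches an exchange of the amino group, and the single measured step, a step that the two limits leave unreadable from compound 1 to compound 3, yields no size. In this assay the step that the limit leaves unreadable from compound 3 to compound 4 is therefore expected to be none beyond the scatter. For compound 4 the estimated value in this assay is 600000 nM, with a range from 200000 nM to 2000000 nM, most likely again reported only as a limit.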

Compound 4, half-maximal inhibitory concentration: > 500000 nM
Compound 4 was reported as a limit (the forecaster's own chance of this, stated with the estimate: 85%); the middle value lies beyond the limit too.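

The step from compound 3 to compound 4 cannot be read, and no order between the two follows, because both stand only at a limit: the limit of > 500000 nM in this assay, at which 4 of the 4 values shown sit.

The compounds shown leave open whether any group on the shared core gives a measurable value in this assay.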